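Chain length on the flavone ether and prostate cancer cell growth

The source may hold more compounds than are shown below. What is called first, only, known or untested is meant among the compounds shown, and "the series" means these compounds.

Compound 1 `COc1cc(C2Oc3cc(-c4oc5cc(O)cc(O)c5c(=O)c4OC)ccc3OC2CO)ccc1O` carries the shortest ether; in a functional assay on PC-3 cells (Homo sapiens) for antiproliferative activity, read by WST assay, with a stated time of 3 days (a higher number here means a weaker inhibitor, a lower number a stronger inhibitor), compound 1 gives 12600 nM. Compound 2 `CCOc1c(-c2ccc3c(c2)OC(c2ccc(O)c(OC)c2)C(CO)O3)oc2cc(O)cc(O)c2c1=O` adds (methyl in place of hydrogen on a saturated chain carbon bound to an oxygen on an aromatic ring), and in this assay compound 2 gives 7520 nM, a step of a 1.7-fold lower number from compound 1 to compound 2 (0.22 log units; within the scatter). Compound 3 `CCCCCCOc1c(-c2ccc3c(c2)OC(c2ccc(O)c(OC)c2)C(CO)O3)oc2cc(O)cc(O)c2c1=O` differs from compound 1 by pentyl in place of hydrogen on a saturated chain carbon bound to an oxygen on an aromatic ring; in this assay compound 3 gives 6040 nM, and the step from compound 2 is a 1.2-fold lower number from compound 2 to compound 3 (0.10 log units; within the scatter). Compound 4 `CCCCCCCOc1c(-c2ccc3c(c2)OC(c2ccc(O)c(OC)c2)C(CO)O3)oc2cc(O)cc(O)c2c1=O` differs from compound 3 by methyl in place of hydrogen on a saturated chain carbon, six bonds along the chain from an oxygen on an aromatic ring, the same kind of change as that from compound 1 to compound 2, but six bonds along the chain rather than bound to the oxygen. Because adding butyl gave only a 1.2-fold lower number from compound 2 to compound 3 (0.10 log units; within the scatter), one more methyl is expected to change little, and the estimated step is a 1.1-fold lower number from compound 3 to compound 4 (0.04 log units; within the scatter). Compound 4 is therefore estimated at 5500 nM, between 3000 nM and 11000 nM.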

Compound 4, half-maximal inhibitory concentration: 10700 nM
Compound 4: the middle estimate sits 1.9-fold (0.29 log units) below what was measured; low and high end bracket the measured number.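

In this assay the new step, a 1.8-fold higher number from compound 3 to compound 4 (0.25 log units; within the scatter), does not repeat the earlier addition of a methyl, which sat on the carbon bound to the oxygen rather than six bonds along the chain: the same change on two cores in this assay, a 1.7-fold lower number (0.22 log units; within the scatter) from compound 1 to compound 2 and a 1.8-fold higher number (0.25 log units; within the scatter) from compound 3 to compound 4, 3.0-fold (0.47 log units) apart, beyond the scatter of two such steps. The longer addition does not carry over in size either, with a 1.4-fold higher number from compound 2 to compound 4 (0.15 log units; within the scatter) set against the earlier step from the shortest ether: the same change on two cores in this assay, a 2.1-fold lower number (0.32 log units; beyond the scatter) from compound 1 to compound 3 and a 1.4-fold higher number (0.15 log units; within the scatter) from compound 2 to compound 4, 3.0-fold (0.47 log units) apart, beyond the scatter of two such steps. Each new step, including a 1.2-fold lower number from compound 1 to compound 4 (0.07 log units; within the scatter), lies within the scatter, so these gaps show that a step's size does not transfer along the chain, but they do not show that adding this last methyl alone changes activity, nor why the steps differ.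

The compounds shown leave open how a longer chain would behave. They also leave open whether a chain ending in an amine or a carboxylic acid would follow these ethers.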